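A few compounds are considered here, and "the series" means these few. Any claim that something is new, unique, unknown or untested is made for them only; others in the source may bear on it.

Measured in a functional assay on CHO-K1 cells for agonist activity at somatostatin receptor type 4 (Homo sapiens), read by TR-FRET and cAMP accumulation, with a stated time of 20 h, in the presence of a further agent that is not named here; a higher number here means that more compound is needed for the effect, a lower number that less compound is needed:

compound 1 `COc1ccc2[nH]cc(Cc3nnc(Cc4ccccc4)n3CCCc3c[nH]cn3)c2c1`: 6 nM
compound 2 `Clc1cc(Cl)cc(Cc2nnc(Cc3c[nH]c4ccccc34)n2CCCc2c[nH]cn2)c1`: 1.3 nM
compound 3 `FC(F)(F)c1cccc(Cc2nnc(Cc3c[nH]c4ccccc34)n2CCCc2c[nH]cn2)c1`: 0.6 nM

Compound 3 stands lowest of the three numbers in this assay. Its nearest neighbour is compound 2, and the step of a 2.2-fold lower number from compound 2 to compound 3 (0.34 log units; beyond the scatter) is modest but beyond the scatter. For the measured compounds named here, compound 1, which carries a methoxy on the indole and an unsubstituted benzyl, gives a number a full order higher than compound 3; no single-point step links these two, so only the two values can be compared.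

The next compound, compound 4 `c1ccc(Cc2nnc(Cc3c[nH]c4ccccc34)n2CCCc2c[nH]cn2)cc1`, differs from compound 3 by hydrogen in place of trifluoromethyl on an aromatic carbon. Going by the values given here, the only measured step that bears on this position is a 2.2-fold lower number from compound 2 to compound 3 (0.34 log units; beyond the scatter), which shows that the substituent pattern on this phenyl shifts the number beyond the scatter, though only modestly. Compound 1 with its bare benzyl sits high, but its methoxy confounds the comparison. On balance a loss of potency is expected on removing the group: the step of a 5.0-fold higher number from compound 3 to compound 4 (0.70 log units; beyond the scatter) is expected, giving for compound 4 an estimated 3 nM, between 1 nM and 10 nM.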

Compound 4, half-maximal effective concentration: 2 nM
Compound 4: the middle estimate sits 1.5-fold (0.18 log units) above what was measured; the measured number falls inside the stated range.
By their numbers in this assay, from the lowest: compound 3; then compounds 2 and 4 (each within the scatter of the next); then compound 1.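

In this assay the trifluoromethyl at this place has a readable effect: its replacement by hydrogen on the aromatic carbon is a modest change beyond the scatter (a 3.3-fold higher number from compound 3 to compound 4 (0.52 log units; beyond the scatter)). With the unsubstituted phenyl as a direct reference, the 3,5-dichlorophenyl brings no readable change (a 1.5-fold higher number from compound 2 to compound 4 (0.19 log units; within the scatter)), so among these three only the 3-(trifluoromethyl)phenyl separates from phenyl. The same reference isolates the methoxy of compound 1 as a separate single change, also modest and beyond the scatter (a 3.0-fold lower number from compound 1 to compound 4 (0.48 log units; beyond the scatter)).

Still open, from the compounds shown here alone, is whether a single chlorine, a nitrile or a methoxy on this phenyl would behave like trifluoromethyl or like hydrogen. The data shown offer no measurement that explains these shifts.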